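This account rests on a few compounds, and the source may have more. Where it says the series, first, only, none or still open, it means among the compounds named here.

Compound 1 `O=C1Oc2ccccc2N/C1=C\C(=O)c1ccncc1` and compound 2 `O=C1Oc2ccccc2N/C1=C\C(=O)c1cccc(Cl)c1` share the same core and differ only in the aromatic ring attached to the carbonyl carbon. In an ADME assay on Vero cells (Chlorocebus sabaeus) for cytotoxicity, read by MTT assay, with a stated time of 72 h (a lower number here means that less compound is tolerated, a higher number that more compound is tolerated), compound 1 gives only a limit, > 1870000 nM. That limit is the one at the limit of > 1870000 nM in this assay, at which 1 of the 2 values shown sits. In this assay, for the measured compounds named here, compound 2 gives 1610000 nM, the only full number among the two values shown. Going by the values given here, the single measured step, an at least 1.1-fold lower number from compound 1 to compound 2 (0.06 log units; that floor lies within the scatter), came with 3-chlorophenyl in place of pyridin-4-yl on a carbonyl carbon, and its floor lies within the scatter, so it shows no clear movement.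

Compound 3 `Cc1cccc(C(=O)/C=C2\Nc3ccccc3OC2=O)c1` differs from compound 2 by methyl in place of chloro on an aromatic carbon. The measured step swapped an entire ring and still gave no movement beyond the scatter, and the change to compound 3 is confined to one heavy atom on that ring, so no step beyond the scatter is expected here either. The expected step from compound 2 to compound 3 is a 1.1-fold higher number from compound 2 to compound 3 (0.05 log units; within the scatter). Compound 3 is therefore estimated at 1800000 nM in this assay, with a range from 900000 nM to 3700000 nM.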

Compound 3, half-maximal cytotoxic concentration: > 1790000 nM
Compound 3 gave a limit, no number; the forecaster's own chance of this, stated with the estimate: 40%; the middle value is on the limit's open side.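

In this assay compound 3 gives > 1790000 nM, which is a limit and not a number. Methyl in place of chloro on this aromatic carbon, meta to a large group, gives an at least 1.1-fold higher number from compound 2 to compound 3 (0.04 log units; that floor lies within the scatter), so only the smallest possible size of the step can be read, and it shows no clear movement at this place. The step between compound 1 and compound 3 cannot be read because both values are limits: the limit of > 1790000 nM in this assay, at which 1 of the 3 values shown sits, and the limit of > 1870000 nM in this assay, at which 1 of the 3 values shown sits.

The compounds shown carry only chloro or methyl at this place on the ring, so it remains open whether a group of a different kind there, such as an amine or a carboxylic acid, would bring the number in this assay clearly down. From the compounds shown here alone, it also remains open how far the true value of compound 3 lies from that of compound 2, since only a full number for compound 3 could settle the size of this change.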